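Swapping a Small Alkyne for a Fluorophenyl Triazole

The source may hold more compounds than are shown below. What is called first, only, known or untested is meant among the compounds shown, and "the series" means these compounds.

Going by the values given here, compound 2 `C#CCN1CCN(c2cccc3[nH]c(-c4ccc(C(C)(C)C)cc4)nc23)CC1` is the one compound here with a plain number: in a functional assay on cells for antagonist activity at Gonadotropin-releasing hormone receptor (Homo sapiens), read by FLIPR and calcium flux, with a stated time of 15 min (on this read-out higher numbers stand for weaker inhibition and lower numbers for stronger inhibition), compound 2 gives 20000 nM. Compound 1 `CC(C)(C)c1ccc(-c2nc3c(N4CCN(Cc5cn([C@@H]6O[C@H](CO)[C@@H](O)[C@H](O)[C@H]6O)nn5)CC4)cccc3[nH]2)cc1` belongs to the same series but differs from compound 2 in more than one place. In this assay compound 1 gives > 10000 nM, which is a limit of the assay and not a number, as noted in the limit of > 10000 nM in this assay, at which 1 of the 2 values shown sits. Compound 3 `CC(C)(C)c1ccc(-c2nc3c(N4CCN(Cc5cn(-c6ccc(F)cc6)nn5)CC4)cccc3[nH]2)cc1` has not yet been measured. It differs from compound 2 by a single change: 1-(4-fluorophenyl)-1H-1,2,3-triazol-4-yl in place of ethynyl on a saturated chain carbon bound to an amine nitrogen in a ring. Among the compounds with values here, compound 1 also carries a 1,2,3-triazole group, though with a different substituent on it, so the two measured compounds give no step of their own to lean on. The move from compound 2 to compound 3 is expected to stay within the usual scatter, estimated as a 1.7-fold lower number from compound 2 to compound 3 (0.22 log units; within the scatter). Compound 3 is therefore expected to give 12000 nM, with a range from 2500 nM to 40000 nM.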

Compound 3, half-maximal inhibitory concentration: 20000 nM
For compound 3 the middle estimate is 1.7-fold (0.22 log units) below the measured one; the range from low to high includes it.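

In this assay, putting 1-(4-fluorophenyl)-1H-1,2,3-triazol-4-yl in place of ethynyl on a saturated chain carbon bound to an amine nitrogen in a ring gives no change at the digits printed from compound 2 to compound 3 (within the scatter). This position therefore accepts a much larger group, with two aromatic rings where ethynyl has none, but the larger group brings no gain in inhibition. The step that involves compound 1 cannot be read, because the value of compound 1 is a limit of the assay and not a number: the limit of > 10000 nM in this assay, at which 1 of the 3 values shown sits.

The compounds shown leave open whether any group at this position can give a clearly lower number. A carboxylic acid or an amine on the triazole, in place of 4-fluorophenyl, would be one way to test this, and so would a simple methyl group there.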